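The source may hold more compounds than are shown below. What is called first, only, known or untested is meant among the compounds shown, and "the series" means these compounds.

Measured in an ADME assay on the whole organism for pharmacokinetics, with Canis familiaris (Canis lupus familiaris) as the target, at a dose of 1 mg/kg by the oral route; a higher number here means more compound in the circulation at the dose given, a lower number less compound in the circulation:
- compound 1 `N#Cc1ccc(Cn2cncc2CN2CCN(c3cccc(Cl)c3)C(=O)C2=O)cc1`: 5250 ng.h/mL
- compound 2 `CCCC[C@H]1CN(c2cccc(C)c2C)C(=O)C(=O)N1Cc1cncn1Cc1ccc(C#N)cc1`: 2000 ng.h/mL

Compound 2 has the lower of the two numbers, and its gap to compound 1 lies beyond the scatter. Compound 3 `Cc1cccc(N2CCN(Cc3cncn3Cc3ccc(C#N)cc3)C(=O)C2=O)c1C` has hydrogen in place of butyl on a saturated ring carbon. Within the data shown here, no single-change step has been measured in this assay, so the evidence is thin. Compound 1, which also lacks the butyl but has a different aryl group, gives 5250 ng.h/mL, which points upward. A modest rise close to the scatter is expected, a 1.6-fold higher number from compound 2 to compound 3 (0.20 log units; within the scatter). For compound 3 the estimated value is 3200 ng.h/mL, with an expected range of 1100 ng.h/mL to 9000 ng.h/mL.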

Compound 3, area under the concentration-time curve in the Canis familiaris assay: 1830 ng.h/mL
Beside the measured number, compound 3's estimate is 1.7-fold (0.24 log units) above it; measured number inside the range.
By their numbers in the Canis familiaris assay, from the lowest: compounds 3 and 2 (each within the scatter of the next); then compound 1.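

With hydrogen in place of butyl on this saturated ring carbon, the Canis familiaris assay gives a 1.1-fold lower number from compound 2 to compound 3 (0.04 log units; within the scatter). In a physicochemical assay for lipophilicity (on this read-out higher numbers stand for higher lipophilicity and lower numbers for lower lipophilicity), compound 2 gives 3.3 and compound 3 gives 1.11. The same pair differs widely in the physicochemical assay, yet that gap brings no matching gap in the circulation numbers: the measured partition coefficient of compound 2, 3.3, and of compound 3, 1.11, a number 2.19 log units lower (beyond the scatter) In the Canis familiaris assay the aryl group is the place that shows a gap: a 2.9-fold lower number from compound 1 to compound 3 (0.46 log units; beyond the scatter).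

From the compounds shown here alone, whether a longer chain or an amine on this ring carbon would read like butyl or hydrogen stays open. So does whether the aryl gap holds with butyl present, since compound 1 and compound 2 differ in more than one place.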